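Swapping a nitro for a methoxy on the ester ring

The source may hold more compounds than are shown below. What is called first, only, known or untested is meant among the compounds shown, and "the series" means these compounds.

Compound 1 `CC1=CC[C@H](C(C)C)c2cc(C)c(OC(=O)Nc3ccccc3)cc21` carries an anilino group on its carbonyl carbon, and in a functional assay on PC-3 cells (Homo sapiens) for antiproliferative activity, read by sulforhodamine B assay, with a stated time of 48 h, tested at 50 uM (a higher number here means more inhibition at the concentration tested (going by the name of the read-out), a lower number less inhibition), compound 1 gives 93.2%. With phenyl in its place, compound 2 `CC1=CC[C@H](C(C)C)c2cc(C)c(OC(=O)c3ccccc3)cc21` gives 22.5%, the step being a number 70.7 percentage points lower from compound 1 to compound 2 (beyond the scatter). Compound 3 `CC1=CC[C@H](C(C)C)c2cc(C)c(OC(=O)c3cccc([N+](=O)[O-])c3)cc21` carries 3-nitrophenyl and gives 36.9%; the steps are a number 56.3 percentage points lower from compound 1 to compound 3 (beyond the scatter) and a number 14.4 percentage points higher from compound 2 to compound 3 (beyond the scatter). Among the three numbers compound 3 stands second highest, beyond the scatter below compound 1 and above compound 2. Compound 4 `COc1ccc(C(=O)Oc2cc3c(cc2C)[C@@H](C(C)C)CC=C3C)cc1` alters the ester ring once more: 4-methoxyphenyl in place of 3-nitrophenyl on a carbonyl carbon. For the measured compounds named here, no measured step involves a methoxy, so only the two ester steps and the nitro step bear on it, and the esters both sit low. Compound 4 is therefore expected to remain near the esters, the step of a number 11.9 percentage points lower from compound 3 to compound 4 (beyond the scatter) being the estimate. For compound 4 the expected value is 25%, with a range from 10% to 45%.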

Compound 4, a percentage reported as inhibition, at one concentration (the size of the read-out at that concentration, not a potency): 60.6%
Beside the measured number, compound 4's estimate is 35.6 percentage points below it; the whole stated range lies below it.
By their numbers in this assay, from the lowest: compound 2; then compound 3; then compound 4; then compound 1.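

Esters on this carbonyl carbon need not stay low in this assay: methoxy in place of hydrogen on the aromatic ring gives a number 38.1 percentage points higher from compound 2 to compound 4 (beyond the scatter), and 4-methoxyphenyl in place of 3-nitrophenyl gives a number 23.7 percentage points higher from compound 3 to compound 4 (beyond the scatter). Even so, the anilino group stays ahead, with a number 32.6 percentage points lower from compound 1 to compound 4 (beyond the scatter). Nothing measured here explains these steps. As far as these compounds go, whether an ethoxy or a dimethylamino group in place of methoxy would hold this gain remains open, as does the effect of methoxy on the anilino ring of compound 1.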